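A few compounds are considered here, and "the series" means these few. Any claim that something is new, unique, unknown or untested is made for them only; others in the source may bear on it.

Measured compounds in a functional assay on SR cells (Homo sapiens) for inhibition, read by sulforhodamine B assay, with a stated time of 48 h; a higher number here means a weaker inhibitor of growth, a lower number a stronger inhibitor of growth:
- compound 1 `CCOC(=O)C(=Cc1c(-c2ccccc2)[nH]c2ccccc12)C(=O)OCC`: 2100 nM
- compound 2 `CC(=O)/C(=C\c1c(-c2ccccc2)[nH]c2ccccc12)S(=O)(=O)c1ccccc1`: "not determined" (no result reported)

For the measured compounds named here, compound 1 is the only member of this set with a number behind it: in this assay compound 1 gives 2100 nM. Compound 2 shares the core of compound 1 but carries an acetyl and a phenylsulfonyl on the double-bonded chain; in this assay compound 2 is recorded as "not determined" (no result reported), so no single number places it, and nothing can be said of how it compares with compound 1.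

Compound 3 `N#C/C(=C\c1c(-c2ccccc2)[nH]c2ccccc12)S(=O)(=O)c1ccccc1` is not yet measured. It differs from compound 2 in one place: cyano in place of acetyl on a double-bonded chain carbon bound to a double-bonded chain carbon and a sulfonyl sulfur. Going by the values given here, no step between measured compounds shows what this exchange does, and with compound 2 itself without a number, the direction of the step in this assay cannot be read from the data; the expectation is for no step beyond the scatter, in either direction. Among the compounds with values here, the only anchor is compound 1 with 2100 nM. On that basis compound 3 is expected to give about 2000 nM, in a range from 400 nM to 10000 nM.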

Compound 3, concentration for 50% growth inhibition: 17300 nM
Compound 3: middle estimate off by 8.7-fold (0.94 log units), on the low side; the measured number lies above the stated range.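

In this assay, for the compounds shown here, compound 3 gives 17300 nM, but compound 2 has no number, so no step from compound 2 to compound 3 can be read. On these data alone, what cyano in place of acetyl does to growth inhibition therefore stays open. No measured evidence shown here bears on this result.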